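Swapping Cyclopropylamino for Pentyloxy: Expected Cell Tolerance

The source may hold more compounds than are shown below. What is called first, only, known or untested is meant among the compounds shown, and "the series" means these compounds.

Three compounds on one shared core were tested in an ADME assay on Akata cells (Homo sapiens) for cytotoxicity, with a stated time of 7 days; a lower number here means that less compound is tolerated, a higher number that more compound is tolerated. Compound 1 `CCCCCCCCOc1nc(N)nc2c1ncn2/C=C1/CC1(CO)CO` carries an octyloxy group; in this assay compound 1 gives > 20000 nM, which is a limit of the assay and not a number. Compound 2 `Nc1nc(OCc2ccccc2)c2ncn(/C=C3/CC3(CO)CO)c2n1` carries a benzyloxy group; in this assay compound 2 gives > 20000 nM, again only a limit. Compound 3 `Nc1nc(NC2CC2)c2ncn(/C=C3/CC3(CO)CO)c2n1` carries a cyclopropylamino group; in this assay compound 3 gives > 20000 nM, also a limit. Compound 3 thus stands exactly where the others stand, namely at the limit of > 20000 nM in this assay, at which 3 of the 3 values shown sit. The steps a step that the two limits leave unreadable from compound 1 to compound 2, a step that the two limits leave unreadable from compound 1 to compound 3 and a step that the two limits leave unreadable from compound 2 to compound 3 therefore carry no readable size.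

Compound 4 `CCCCCOc1nc(N)nc2c1ncn2/C=C1/CC1(CO)CO` differs from compound 3 as follows: pentyloxy in place of cyclopropylamino on an aromatic carbon. Among the compounds with values here, no measured step can be sized, so none predicts a direction; the values only show that every compound, including compound 1 with its octyloxy chain, sits at the limit. The expected step is a step that the limit leaves unreadable from compound 3 to compound 4, most likely nothing readable. Compound 4 is estimated at 40000 nM (range 20000 nM to 150000 nM), very probably reported once more as a limit.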

Compound 4, half-maximal cytotoxic concentration: > 20000 nM
Compound 4: no number, only a limit; the forecaster's own chance of this, stated with the estimate: 90%; the middle value is on the limit's open side.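

In this assay compound 4 gives > 20000 nM and this is a limit, not a number. The steps to it from compound 1, compound 2 and compound 3 therefore cannot be read: the limit of > 20000 nM in this assay, at which 4 of the 4 values shown sit.

The compounds shown leave open whether octyloxy, benzyloxy, cyclopropylamino and pentyloxy differ at all in this read-out.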